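Cytotoxicity limits across two fused bicyclic cores

This account rests on a few compounds, and the source may have more. Where it says the series, first, only, none or still open, it means among the compounds named here.

Compound 1 `CCCCc1cc2cn(COCCO)c(=O)nc2o1` and compound 2 `O=c1nc2occc2cn1COCCO` share one core; compound 3 `CCCCc1cc2cn(COCCO)c(O)nc-2n1` and the unmeasured compound 4 `OCCOCn1cc2ccnc-2nc1O` share another. How the core of compound 1 and the core of compound 3 differ is not broken down here.

In a functional assay on HEL cells (Homo sapiens), read by microscopy (a lower number here means that less compound is tolerated, a higher number that more compound is tolerated), compound 1 gives > 400000 nM, which is a limit of the assay and not a number. Compound 2 gives > 400000 nM, again a limit. Compound 3 gives > 400000 nM, also a limit. Thus the limit of > 400000 nM in this assay, at which 3 of the 3 values shown sit, is the only evidence available on the series.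

The change from compound 1 to compound 2 is hydrogen in place of butyl on an aromatic carbon. Its effect is a step that the two limits leave unreadable from compound 1 to compound 2, so the size of this step cannot be read from the two values.

The change from compound 3 to compound 4 is hydrogen in place of butyl on an aromatic carbon. It is the same kind of change as that from compound 1 to compound 2, not the same: in the first the place is on a five-membered aromatic ring with 1 oxygen, next to the ring oxygen, whereas here it is on a five-membered aromatic ring with 1 nitrogen, next to the ring nitrogen.

For compound 4 a step of a number no higher from compound 3 to compound 4 (the limit leaves the size open) is expected, resting on compound 3 sitting at > 400000 nM and on (the limit of > 400000 nM in this assay, at which 3 of the 3 values shown sit). Compound 4 is therefore estimated at 400000 nM, most likely reported as a limit again, within 200000 nM to 800000 nM.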

Compound 4, minimum cytotoxic concentration: > 400000 nM
Compound 4: a limit, no number; the forecaster's own chance of this, stated with the estimate: 85%; the middle value lies on the limit itself.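

Within the data shown here, no new step can be read: compound 3 and compound 4 both stand at a limit of the assay and not at a number, so the step between them stays as unreadable as the one between compound 1 and compound 2. The compounds shown leave open whether butyl, hydrogen or either core makes any difference to the concentration tolerated in this assay, with every value at one limit: the limit of > 400000 nM in this assay, at which 4 of the 4 values shown sit.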